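Removing a Hydroxy Group from Compound 3

The source may report more compounds than this note shows. Statements on the series, on what has been measured and on what is new or still open speak of the compounds shown alone.

Of the compounds shown here, three sharing one core have been measured in an ADME assay on HT-29 cells (Homo sapiens) for cytotoxicity, read by MTT assay, with a stated time of 72 h; on this read-out lower numbers stand for stronger inhibition and higher numbers for weaker inhibition: compound 1 (`COc1ccc(C2=C(c3cc(OC)c(OC)c(OC)c3)C(=O)C(O)C2)cc1`), compound 2 (`COC(=O)c1cc(C2=C(c3cc(OC)c(OC)c(OC)c3)C(=O)CC2O[SiH2]C(C)(C)C)ccc1OC`) and compound 3 (`COc1ccc(C2=C(c3cc(OC)c(OC)c(OC)c3)C(=O)CC2O)cc1O`). Compound 1 gives < 1 ug/mL, which is a limit of the assay and not a number. Compound 2 gives > 100 ug/mL, which is also a limit. Compound 3 gives < 1 ug/mL, again a limit and not a number. Going by these compounds, compound 3 therefore stands on (the limit of < 1 ug/mL in this assay, at which 2 of the 3 values shown sit), so its exact value in this assay remains unknown.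

Compound 4 (`COc1ccc(C2=C(c3cc(OC)c(OC)c(OC)c3)C(=O)CC2O)cc1`) differs from compound 3 as follows: hydrogen in place of hydroxy on an aromatic carbon. This places hydrogen in place of hydroxy on an aromatic carbon, turning 3-hydroxy-4-methoxyphenyl into 4-methoxyphenyl. Among the measured compounds shown here, no measured pair isolates this change, so nothing shows its size directly. The expected change is a step that the limit leaves unreadable from compound 3 to compound 4, and no step beyond the scatter is expected in either direction. The estimated value for compound 4 is 0.6 ug/mL, with an expected range from 0.1 ug/mL to 2 ug/mL.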

Compound 4, half-maximal inhibitory concentration: 15 ug/mL
Compound 4: middle estimate off by 25-fold (1.40 log units), on the low side, outside the stated range (above it).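

In this assay, the hydroxy of the 3-hydroxy-4-methoxyphenyl group turns out to matter: putting hydrogen in its place gives an at least 15-fold higher number from compound 3 to compound 4 (1.17 log units; beyond the scatter), a large step beyond the scatter. The earlier compounds shown here included no pair that isolated this change, and this pair shows that the aromatic carbon ortho to a methoxy group does not tolerate losing its hydroxy without a clear weakening of inhibition. The step can only be read as a minimum because compound 3 sits on a limit: the limit of < 1 ug/mL in this assay, at which 2 of the 4 values shown sit.

The compounds shown do not tell why the loss of this hydroxy weakens inhibition. Going by these compounds, it also stays open whether another group at this position, such as an amine, a fluorine or a carboxylic acid, would keep the inhibition of compound 3 or lose it as hydrogen does.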